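This account rests on a few compounds, and the source may have more. Where it says the series, first, only, none or still open, it means among the compounds named here.

Compound 1 `Cc1ccc(C2=NN(c3ccc(S(C)(=O)=O)cc3)C(=O)CC2)cc1`: 610 nM
Compound 2 `Cc1cc(O)ccc1C1=NN(c2ccc(S(C)(=O)=O)cc2)C(=O)CC1`: 5650 nM

In a functional assay on UACC-257 cells (Homo sapiens) for inhibition, read by sulforhodamine B assay, with a stated time of 48 h (a higher number here means a weaker inhibitor of growth, a lower number a stronger inhibitor of growth), compound 2 gives 5650 nM, the higher of the two numbers. Compound 3 `CCc1ccc(C2=NN(c3ccc(S(C)(=O)=O)cc3)C(=O)CC2)cc1` carries 4-ethylphenyl in place of 4-hydroxy-2-methylphenyl on a carbon with a double bond to nitrogen. For the measured compounds named here, one measured step bears on this change: a 9.3-fold higher number from compound 1 to compound 2 (0.97 log units; beyond the scatter), which is beyond the scatter. With 4-hydroxy-2-methylphenyl leaving, a step of similar size towards a lower number is expected in this assay, returning close to compound 1 at 610 nM. The expected step is a 7.1-fold lower number from compound 2 to compound 3 (0.85 log units; beyond the scatter). For compound 3 the estimated value is 800 nM, within an expected range of 300 nM to 2500 nM.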

Compound 3, concentration for 50% growth inhibition: 3300 nM
For compound 3 the middle estimate is 4.1-fold (0.62 log units) below the measured one, and the stated range ends below it.
By their numbers in this assay, from the lowest: compound 1; then compounds 3 and 2 (each within the scatter of the next).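

Adding one methyl to the chain of the 4-methylphenyl group of compound 1 is enough to shift the number in this assay, giving a 5.4-fold higher number from compound 1 to compound 3 (0.73 log units; beyond the scatter), so at this position a change need not introduce a hydroxy group to do so. Compound 3 and compound 2 cannot be told apart, with a 1.7-fold lower number from compound 2 to compound 3 (0.23 log units; within the scatter), although 4-ethylphenyl carries no hydrogen-bond donor or acceptor. No measurement at hand explains either step. From the compounds shown here alone, it remains open how a methoxy group, a chlorine or an amine in place of that methyl would read in this assay.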